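A few compounds are considered here, and "the series" means these few. Any claim that something is new, unique, unknown or untested is made for them only; others in the source may bear on it.

Compound 1 `COc1cc(-c2nn(-c3cccc(NC(=O)c4cccc(C(F)(F)F)c4)c3)cc2-c2ccncc2)ccc1Cl` was examined in a functional assay on HCT-15 cells (Homo sapiens) for inhibition, read by sulforhodamine B assay, with a stated time of 48 h; on this read-out lower numbers stand for stronger inhibition of growth and higher numbers for weaker inhibition of growth. In this assay compound 1 gives only a limit, > 50000 nM, and it is the compound sitting at the limit of > 50000 nM in this assay, at which 1 of the 2 values shown sits. Compound 2 `O=C(Nc1cccc(-n2cc(-c3ccncc3)c(-c3ccc(Cl)c(O)c3)n2)c1)Nc1cc(C(F)(F)F)cc(C(F)(F)F)c1` differs in several places; in this assay compound 2 gives 3520 nM. Compound 3 `COc1cc(-c2nn(-c3cccc(NC(=O)c4ccccc4)c3)cc2-c2ccncc2)ccc1Cl` has not yet been measured. Its change from compound 1 is hydrogen in place of trifluoromethyl on an aromatic carbon. Compound 3 is expected to show no step beyond the usual scatter, written as a number no higher from compound 1 to compound 3 (the limit leaves the size open). Compound 3 is therefore estimated at 50000 nM, within 20000 nM to 150000 nM, most likely again reported only as a limit.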

Compound 3, concentration for total growth inhibition: > 100000 nM
Compound 3 gave a limit, no number; the forecaster's own chance of this, stated with the estimate: 70%; middle value at least 2.0-fold (0.30 log units) away from the limit.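

In this assay compound 3 gives only a limit, > 100000 nM. For the compounds shown here, compound 1 also gives only a limit, > 50000 nM, so no step between compound 1 and compound 3 can be read. The compounds shown leave open how hydrogen in place of trifluoromethyl changes growth inhibition.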